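This account rests on a few compounds, and the source may have more. Where it says the series, first, only, none or still open, it means among the compounds named here.

Measured compounds:
compound 2 `Cc1cccc(C(=O)/C=C/c2ccc3c(c2)B(O)OC3)c1` — 2900 nM in a functional assay on SK-OV-3 cells (Homo sapiens) for cytotoxicity, read by MTT assay, with a stated time of 48 h; a higher number here means a weaker inhibitor, a lower number a stronger inhibitor
compound 1 `O=C(/C=C/c1ccc2c(c1)B(O)OC2)c1cccs1` — 10400 nM in this assay

Compound 2 holds the lowest of the two numbers in this assay; its nearest neighbour is compound 1, and the step of a 3.6-fold lower number from compound 1 to compound 2 (0.55 log units; beyond the scatter) lies beyond the scatter, so compound 2 is the stronger of the pair.

Compound 3 `COc1cccc(C(=O)/C=C/c2ccc3c(c2)B(O)OC3)c1` differs from compound 2 in one place: methoxy in place of methyl on an aromatic carbon. Going by the values given here, only one measured step exists, and it concerns the exchange of thiophen-2-yl for 3-methylphenyl on the carbonyl carbon, not a change of the substituent on that ring. It therefore bears on the present step only loosely, showing that the ketone-side aryl group matters, without saying how a methoxy would compare with a methyl. Among the compounds with values here, with no direct precedent, the expected step in this assay is small, in neither direction beyond the scatter.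

On that basis compound 3 is expected to give about 3000 nM in this assay, with a range of 1200 nM to 7500 nM. The estimated step of a 1.0-fold higher number from compound 2 to compound 3 (0.01 log units; within the scatter) is expected to stay within the scatter.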

Compound 3, half-maximal inhibitory concentration: 2600 nM
Beside the measured number, compound 3's estimate is 1.2-fold (0.06 log units) above it, within the range that was stated.
By their numbers in this assay, from the lowest: compounds 3 and 2 (each within the scatter of the next); then compound 1.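

In this assay, putting methoxy in place of methyl on an aromatic carbon of the six-membered aromatic ring of carbon only, meta to a large group, gives a 1.1-fold lower number from compound 2 to compound 3 (0.05 log units; within the scatter), which leaves compound 2 and compound 3 indistinguishable in this read-out. Going by these compounds alone, the earlier step, a 3.6-fold lower number from compound 1 to compound 2 (0.55 log units; beyond the scatter), showed only that exchanging the whole group on the carbonyl carbon can move the number beyond the scatter, whereas this result shows that, at this one position, the added oxygen and the hydrogen-bond acceptor that methoxy brings leave the number within the scatter of that for methyl. No measurement shown here speaks to what lies behind this result.

Methyl and methoxy are only two substituents at one position, so it remains open whether an amine, a carboxylic acid or a longer chain such as butoxy at this position would also stay within the scatter of compound 2 and compound 3. From the compounds shown here alone, it is equally open whether methyl and methoxy would stay level at another carbon of this ring, or whether the same exchange would hold with a different core.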